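Fluoro for Chloro on the Phenoxy Ring

The source may report more compounds than this note shows. Statements on the series, on what has been measured and on what is new or still open speak of the compounds shown alone.

Of the compounds shown here, two share one core and have been tested in a functional assay on the whole organism (strain NMRI) with Mus musculus as the target, with a stated time of 60 min, at a dose of 20 mg/kg by the intraperitoneal route; on this read-out higher numbers stand for a stronger effect at the one dose given and lower numbers for a weaker effect. Compound 1 `CCSc1nnc(Cc2ccc(Cl)cc2Oc2ccccc2F)[nH]1` gives 141% in this assay. Compound 2 `CCOc1nnc(Cc2ccc(Cl)cc2Oc2ccccc2Cl)[nH]1` gives 135% in this assay, and the two numbers lie within the usual scatter of each other, so neither can be ranked above the other on what has been measured.

Compound 3 `CCOc1nnc(Cc2ccc(Cl)cc2Oc2ccccc2F)[nH]1` has not yet been measured. It differs from compound 2 in one place: fluoro in place of chloro on an aromatic carbon. Among the compounds with values here, no pair of measured compounds separates this single change on its own, so its size is not known from the numbers at hand. The nearest guide is that compound 1, which already carries the fluoro, gives 141% in this assay, and that compound 2 with the chloro gives 135%. On that basis the step of a number 3 percentage points higher from compound 2 to compound 3 (within the scatter) is expected to stay within the scatter. Compound 3 is therefore estimated to give 138% in this assay, with a range from 120% to 156%.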

Compound 3, a percentage reported as activity, at one dose (the size of the read-out at that dose, not a potency): 138%
The estimate for compound 3 equals the measured number at the digits printed; measured number inside the range.
By their numbers in this assay, from the lowest: compounds 2, 3 and 1 (each within the scatter of the next).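

Within the data shown here, compound 3 gives the first direct reading of fluoro in place of chloro on this aromatic carbon, ortho to a large group. In this assay the step (a number 3 percentage points higher from compound 2 to compound 3 (within the scatter)) leaves 2-fluorophenoxy and 2-chlorophenoxy indistinguishable at the one dose given. Among these compounds, compound 3 also supplies the first single-place comparison at the other end of the shared core: with the fluoro held constant, the step (a number 3 percentage points lower from compound 1 to compound 3 (within the scatter)) does not separate ethoxy from ethylsulfanyl. Nothing available explains either result.

The compounds shown leave open whether this position tolerates groups other than the two halogens, such as methoxy, trifluoromethyl or an unsubstituted phenoxy ring. They also leave open how an amine or a longer chain in place of the ethoxy would read out, and whether these equivalences would hold at other doses.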